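The source may report more compounds than this note shows. Statements on the series, on what has been measured and on what is new or still open speak of the compounds shown alone.

Measured so far in an assay for inhibition of histone deacetylase 8 (Homo sapiens), read by fluorescence, with stated times of 15 min and 60 min; a lower number here means a stronger inhibitor, a higher number a weaker inhibitor:

compound 1 `Nc1cc(O)ccc1NC(=O)c1ccc(CNc2nccc(-c3cccnc3)n2)cc1` gives > 20000 nM, a limit of the assay
compound 2 `Nc1cc(-c2ccccc2)ccc1NC(=O)c1ccc(CNc2nccc(-c3cccnc3)n2)cc1` gives > 20000 nM, a limit of the assay
compound 3 `COc1ccc(NC(=O)c2ccc(CNc3nccc(-c4cccnc4)n3)cc2)c(N)c1` gives > 20000 nM, a limit of the assay

None of the three values is a number; all three sit at the limit of > 20000 nM in this assay, at which 3 of the 3 values shown sit. Compound 3 therefore stands only as a limit, and the two further values around it are limits as well. The three steps between them, a step that the two limits leave unreadable from compound 1 to compound 2, a step that the two limits leave unreadable from compound 1 to compound 3 and a step that the two limits leave unreadable from compound 2 to compound 3, are consequently unreadable in size and direction.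

Compound 4 `Nc1cc(C(=O)OCc2ccccc2)ccc1NC(=O)c1ccc(CNc2nccc(-c3cccnc3)n2)cc1` is yet to be measured. It differs from compound 3 by benzyloxycarbonyl in place of methoxy on an aromatic carbon. Within the data shown here, no measured step bears readably on this change, since every value so far is a limit. With nothing in the series read as a number, compound 4 is expected to remain at the limit as well, the expected step being a step that the limit leaves unreadable from compound 3 to compound 4. The estimate for compound 4 in this assay is 30000 nM, within a range of 5000 nM to 200000 nM.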

Compound 4, half-maximal inhibitory concentration: > 20000 nM
Compound 4 gave a limit, no number; the forecaster's own chance of this, stated with the estimate: 85%; the middle value does not contradict the limit.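

In this assay, among these compounds, compound 4 gives > 20000 nM as a limit, not a number, and no step among compound 1, compound 2, compound 3 and compound 4 can be read: the limit of > 20000 nM in this assay, at which 4 of the 4 values shown sit.
From the compounds shown here alone, whether any group at this place on the shared core gives a numerical value in this assay remains open.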